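Replacing a thiophene arm with a fluorophenyl on the enone

This account rests on a few compounds, and the source may have more. Where it says the series, first, only, none or still open, it means among the compounds named here.

Measured compounds:
- compound 1, `Cc1ccc(CS/C(=C/c2ccc(C)s2)C(=O)c2ccc(Cl)cc2)cc1`: 50000 nM
- compound 2, `CN(C)c1ccc(/C=C(/SCc2ccc(Cl)cc2)C(=O)c2ccc(Br)cc2)cc1`: 10000 nM
- compound 3, `O=C(/C(=C\c1ccc(O)c([N+](=O)[O-])c1)SCc1ccc(Br)cc1)c1ccc(C(F)(F)F)cc1`: 10000 nM

In a functional assay on DU-145 cells (Homo sapiens) for inhibition, read by trypan blue exclusion, with a stated time of 96 h (on this read-out higher numbers stand for weaker inhibition of growth and lower numbers for stronger inhibition of growth), compound 1 gives 50000 nM, the highest of the three numbers. Compound 2 gives 10000 nM and compound 3 gives 10000 nM, and both of these lie at a distance from compound 1 that is beyond the scatter, so compound 1 is the weakest inhibitor among the three measured compounds. No pair of these compounds differs in a single place, so none of the gaps can be attributed to one change.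

Compound 4, `Cc1ccc(CS/C(=C/c2ccccc2F)C(=O)c2ccc(Cl)cc2)cc1`, has not yet been measured in this assay. It differs from compound 1 in one place: 2-fluorophenyl in place of 5-methylthiophen-2-yl on a double-bonded chain carbon bound to a double-bonded chain carbon. Compounds 2 and 3 both carry a six-membered carbon ring on that double-bonded chain carbon and both give lower numbers than compound 1, but they also differ from compound 1 elsewhere, so this is weak guidance. A modest step toward stronger inhibition is expected, with the estimate a 1.7-fold lower number from compound 1 to compound 4 (0.22 log units; within the scatter), though a result within the scatter of compound 1 would not surprise. Compound 4 is expected to give 30000 nM in this assay, with a range from 10000 nM to 80000 nM.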

Compound 4, concentration for 50% growth inhibition: 10000 nM
Compound 4: middle estimate off by 3.0-fold (0.48 log units), on the high side; the measured number falls inside the stated range.
By their numbers in this assay, from the lowest: compounds 2, 3 and 4 (each within the scatter of the next); then compound 1.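

In this assay, going by these compounds alone, putting 2-fluorophenyl in place of 5-methylthiophen-2-yl on a double-bonded chain carbon bound to a double-bonded chain carbon gives a 5.0-fold lower number from compound 1 to compound 4 (0.70 log units; beyond the scatter), and this is the first gap that can be tied to a single change. Compounds 2 and 3 also carry a six-membered carbon ring at this place, but they differ from compound 1 elsewhere as well, so they could not show whether the place itself matters. With the rest of compound 1 held fixed, compound 4 shows that the group at this place alone can move the read-out beyond the scatter, although nothing available here explains the size or direction of this step.

The compounds shown do not separate the fluorine from the exchange of the five-membered ring for the six-membered one, a question that a plain phenyl or an unsubstituted thiophen-2-yl at this place would address. They also leave open whether the same exchange gives a similar step when the groups elsewhere on the shared core are different.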